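The source may report more compounds than this note shows. Statements on the series, on what has been measured and on what is new or still open speak of the compounds shown alone.

Measured so far:
Compound 1 `O=C(O)/C=C/c1ccc(NCc2cccc(Oc3ccccc3)c2)cc1` — 76%
Compound 2 `O=C(O)COc1ccc(NCc2cccc(Oc3ccccc3)c2)cc1` — 84%

In a functional assay on CHO cells for agonist activity at Free fatty acid receptor 1 (Homo sapiens), read by a luciferase reporter (on this read-out lower numbers stand for smaller maximal responses and higher numbers for larger maximal responses), compound 1 gives 76%, and compound 2 gives 84%; the step of a number 8 percentage points higher from compound 1 to compound 2 (within the scatter) lies within the scatter, so on these two numbers compound 2 stands level with compound 1. Compound 3 `CC(Cc1ccc(NCc2cccc(Oc3ccccc3)c2)cc1)C(=O)O` carries 2-carboxypropyl in place of carboxymethoxy on an aromatic carbon. Among the compounds with values here, only one measured step bears on this change, and it shows that exchanging the group at this position left the maximal response within the scatter. Compound 3 is therefore expected to give 80%, in the range 62% to 98%, a step of a number 4 percentage points lower from compound 2 to compound 3 (within the scatter) that is expected to stay within the scatter.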

Compound 3, largest response reached (reported as percent of maximum), in percent of the reference or control that the assay uses: 70%
Beside the measured number, compound 3's estimate is 10 percentage points above it, and the stated range covers the measured number.
By their numbers in this assay, from the lowest: compounds 3, 1 and 2 (each within the scatter of the next, the first and the last beyond it).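

In this assay, the exchange at this position, on an aromatic carbon para to a large group, now gives a step beyond the scatter, a number 14 percentage points lower from compound 2 to compound 3 (beyond the scatter), though a modest one. The maximal response therefore does depend on the group here, yet not for every pair, as 2-carboxypropyl against 2-carboxyethenyl gives only a number 6 percentage points lower from compound 1 to compound 3 (within the scatter), within the scatter. No available evidence accounts for this difference.

Still open, going by these compounds, is how a primary amide would fare in place of the carboxylic acid, or how a longer chain would behave, such as 4-carboxybutyl.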